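The compounds below may be only part of what the source reports. "The series", "measured", "known", "first", "only" and "open" are said of these compounds alone.

Measured compounds:
compound 1 `CCCCC(Sc1nc(Cl)cc(Nc2nc(-c3ccc(Cl)cc3)cs2)n1)C(=O)O` with 900 nM in an assay for inhibition of Polyunsaturated fatty acid 5-lipoxygenase (Homo sapiens), read by HPLC, with stated times of 15 min and 10 min; a higher number here means a weaker inhibitor, a lower number a stronger inhibitor
compound 2 `CCC(Sc1nc(Cl)cc(Nc2nc(-c3ccc(Cl)cc3)cs2)n1)C(=O)O` with 3600 nM
compound 3 `CCCCCCC(Sc1nc(Cl)cc(Nc2nc(-c3cccc4ccccc34)cs2)n1)C(=O)O` with 400 nM

Compound 3 gives the lowest number of the three: compound 1 stands at a higher number beyond the scatter, and compound 2 higher still. Among the measured compounds shown here, the one single-point step measured, a 4.0-fold higher number from compound 1 to compound 2 (0.60 log units; beyond the scatter), concerns the chain next to the acid and not the aromatic group, so it does not bear on the change at hand. Compound 4 `CCCCCCC(Sc1nc(Cl)cc(Nc2nc(-c3ccc([N+](=O)[O-])cc3)cs2)n1)C(=O)O` differs from compound 3 in 4-nitrophenyl in place of naphthalen-1-yl on an aromatic carbon. Compounds 1 and 3 carry different aromatic groups but differ in the chain as well, so their values alone cannot separate the two effects. With no direct guide, a small step toward a higher number, a 1.8-fold higher number from compound 3 to compound 4 (0.24 log units; within the scatter), is expected, and compound 4 is estimated at 700 nM, between 250 nM and 2500 nM.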

Compound 4, half-maximal inhibitory concentration: 1400 nM
Estimate against measurement, compound 4: 2.0-fold (0.30 log units) below; measured number inside the range.
By their numbers in this assay, from the lowest: compound 3; then compounds 1 and 4 (each within the scatter of the next); then compound 2.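

On the aromatic carbon next to the ring nitrogen, 4-nitrophenyl in place of naphthalen-1-yl gives a 3.5-fold higher number from compound 3 to compound 4 (0.54 log units; beyond the scatter) in this assay. Among the compounds shown here, with the chain held the same, this is the first direct sign that the group at this position affects the number, and the step lies beyond the usual scatter. Nothing measured here explains the step. The pair cannot separate the loss of the second ring from the arrival of the nitro group, and a plain phenyl group or a 4-aminophenyl group could help tell those two changes apart.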